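Acetamido to benzamido on the ether side chain

The source may report more compounds than this note shows. Statements on the series, on what has been measured and on what is new or still open speak of the compounds shown alone.

Of the compounds shown here, three with a shared core have been measured in an assay on cells for inhibition of Amine oxidase [flavin-containing] B (Homo sapiens), read by fluorescence and Amplex Red, with stated times of 30 min and 15 min; a higher number here means a weaker inhibitor, a lower number a stronger inhibitor. Compound 1 `C#CCNC1CCc2c(NCc3cccc(Br)c3)cccc21` gives 110 nM, compound 2 `C#CCNC1CCc2c(NCc3cccc(C)c3)cccc21` gives 710 nM, and compound 3 `C#CCNC1CCc2c(OCCc3cc(NC(C)=O)ccc3Cl)cccc21` gives 590 nM. Going by the values given here, the one step between compounds differing in a single place is a 6.5-fold higher number from compound 1 to compound 2 (0.81 log units; beyond the scatter). Compound 3 stands second highest of the three numbers: its nearest neighbour is compound 2, within the scatter, while compound 1 lies beyond the scatter at a lower number.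

Compound 4 `C#CCNC1CCc2c(OCCc3cc(NC(=O)c4ccccc4)ccc3Cl)cccc21` is not yet measured in this assay. It differs from compound 3 by phenyl in place of methyl on a carbonyl carbon, that is, acetyl to benzoyl, acetamido to benzamido. Among the compounds with values here, no measured step bears directly on this change: the only step recorded swaps methyl for bromo on an aromatic carbon of a different side chain, and nothing on record replaces methyl with phenyl on a carbonyl carbon. Within the data shown here, with no comparable precedent, the expectation is a step of a 1.2-fold lower number from compound 3 to compound 4 (0.07 log units; within the scatter), no larger than the scatter in either direction. Compound 4 is therefore estimated at 500 nM, with a range from 150 nM to 2000 nM.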

Compound 4, half-maximal inhibitory concentration: > 20000 nM
Compound 4 was reported as a limit; the forecaster's own chance of this, stated with the estimate: 5%; middle value at least 40-fold (1.60 log units) from the limit.
By their numbers in this assay, from the lowest: compound 1; then compounds 3 and 2 (each within the scatter of the next). At a limit, above all of these: compound 4.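

In this assay, phenyl in place of methyl on a carbonyl carbon turns out to be a sharp change rather than a quiet one, giving an at least 33-fold higher number from compound 3 to compound 4 (1.53 log units; beyond the scatter). Compound 4 gives > 20000 nM, which is a limit of the assay and not a number: the limit of > 20000 nM in this assay, at which 1 of the 4 values shown sits. Going by these compounds alone, the earlier compounds offered only one step, on an aromatic carbon of a different side chain, a 6.5-fold higher number from compound 1 to compound 2 (0.81 log units; beyond the scatter); compound 4 now shows that the group on this carbonyl carbon of the ether side chain also matters, and that here the step is large, where that earlier one was modest.

This single pair leaves open whether the loss follows from the aromatic ring itself or from the added carbons, a question that an ethyl, a cyclopropyl or a cyclohexyl on the same carbonyl carbon would begin to separate. It also leaves open how far the effect depends on the amide link, for which a urea or a sulfonamide in the same place would be the next comparison, and whether a pyridine ring would behave as phenyl does.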